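The source may report more compounds than this note shows. Statements on the series, on what has been measured and on what is new or still open speak of the compounds shown alone.

Two compounds have so far been measured in an ADME assay on BTI cells for inhibition of Amine oxidase [flavin-containing] A (Homo sapiens), read by fluorescence and Amplex Red, with a stated time of 15 min, tested at 100 uM; a higher number here means more inhibition at the concentration tested (going by the name of the read-out), a lower number less inhibition:

Compound 1, `C#CCN(C)CCCCOc1ccc2c(c1)CCC2=O`, gives 7.93%.
Compound 2, `C#CCN(C)CCCCCOc1ccc2c(c1)CCC2=O`, gives 31%.

Within the data shown here, compound 2 stands highest of the two numbers in this assay, and the single step measured so far, a number 23.1 percentage points higher from compound 1 to compound 2 (beyond the scatter), lies beyond the scatter. That step was the replacement of methyl(propargyl)amino by (methyl(propargyl)amino)methyl at the saturated chain carbon four bonds along the chain from the oxygen on the aromatic ring.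

Compound 3, `C#CCN(C)CCCCCCOc1ccc2c(c1)CCC2=O`, has not yet been measured. It differs from compound 2 by (methyl(propargyl)amino)methyl in place of methyl(propargyl)amino on a saturated chain carbon, five bonds along the chain from an oxygen on an aromatic ring. Among the measured compounds shown here, this is the same kind of replacement as the one measured step, only at the next carbon out, so that step is the only guide here; with a single example, the direction is taken from it while the size is held back. A further rise is expected in this assay, estimated as a number 11 percentage points higher from compound 2 to compound 3 (beyond the scatter), smaller than the measured step and possibly within the scatter. For compound 3 the estimate is 42%, with a range from 15% to 68%.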

Compound 3, a percentage reported as inhibition, at one concentration (the size of the read-out at that concentration, not a potency): 4.42%
For compound 3 the middle estimate is 37.6 percentage points above the measured one, outside the stated range (below it).
By their numbers in this assay, from the lowest: compounds 3 and 1 (each within the scatter of the next); then compound 2.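

In this assay, the replacement that raised the number one carbon earlier now reverses direction and gives a number 26.6 percentage points lower from compound 2 to compound 3 (beyond the scatter) so the same change can have opposite outcomes at neighbouring places on the chain. Replacing methyl(propargyl)amino with 2-(methyl(propargyl)amino)ethyl gives a number 3.5 percentage points lower from compound 1 to compound 3 (within the scatter) and so compound 2 alone stands apart among these three, with no steady trend along the series. Nothing available explains why the number falls at this position.

On these data alone, it remains open whether a longer chain than that of compound 3 would stay low or rise again, which would show whether compound 2 marks a single narrow optimum. Also open, as far as these compounds go, is whether an amine carrying an allyl group in place of the propargyl group would follow the same pattern.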